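The compounds below may be only part of what the source reports. "The series", "measured", "known", "first", "only" and "open" are said of these compounds alone.

Measured compounds:
compound 1, `Cc1cc(O)cc(-c2nn(CC#N)cc2-c2ccnc(-c3ccc(Oc4ccccc4)cc3)c2)c1` — 3950 nM
compound 2, `COc1cc(C)cc(-c2nn(CC#N)cc2-c2ccnc(-c3ccc(N(C)C)cc3)c2)c1` — 448 nM

Of the compounds shown here, two have been measured in a functional assay on OVCAR-3 cells (Homo sapiens) for inhibition, read by sulforhodamine B assay, with a stated time of 48 h; on this read-out higher numbers stand for weaker inhibition of growth and lower numbers for stronger inhibition of growth. Compound 2 stands at the lower of the two numbers, and compound 1 stands above it by a gap that is beyond the usual scatter of this assay. For the measured compounds named here, the two differ in more than one place, so no single structural step connects them.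

The next compound to be measured is compound 3, `Cc1cc(O)cc(-c2nn(CC#N)cc2-c2ccnc(-c3ccc(N(C)C)cc3)c2)c1`. It differs from compound 2 in one place only: hydrogen in place of methyl on an oxygen on an aromatic ring. Going by the values given here, for this change no measured step is available, so there is nothing to say about its direction from the data already in hand. The hydroxy group of compound 3 is also carried by compound 1, but compound 1 differs elsewhere as well, so its value cannot be read as a guide to this step.

On that basis the step from compound 2 to compound 3 is expected to be small, most likely within the scatter, a 1.3-fold higher number from compound 2 to compound 3 (0.13 log units; within the scatter). For compound 3 the expected value in this assay is 600 nM, within a range from 200 nM to 2500 nM.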

Compound 3, concentration for total growth inhibition: 4780 nM
Compound 3: middle estimate off by 8.0-fold (0.90 log units), on the low side; the whole stated range lies below it.
By their numbers in this assay, from the lowest: compound 2; then compounds 1 and 3 (each within the scatter of the next).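

In this assay, for the compounds shown here, the change from methoxy to hydroxy, with hydrogen in place of methyl on an oxygen on an aromatic ring, gives an 11-fold higher number from compound 2 to compound 3 (1.03 log units; beyond the scatter) and so counts as a large step, the first reading at this position, which the earlier compounds could not supply. Removing this single methyl, one heavy atom, is therefore enough to move the number well beyond the scatter. With hydroxy kept at this position, dimethylamino in place of phenoxy on an aromatic carbon gives a 1.2-fold higher number from compound 1 to compound 3 (0.08 log units; within the scatter) and so leaves the two compounds indistinguishable in this read-out, and nothing measured here explains either result.

The compounds shown leave open whether methoxy is the particular group that matters on this oxygen, since an ethoxy group, a longer chain or an amine in place of the oxygen would each test this. Going by these compounds alone, they also leave open whether the methoxy to hydroxy step has the same size with phenoxy on the other aromatic ring, as the single step read here carries dimethylamino there.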